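The compounds below may be only part of what the source reports. "The series", "measured", "known", "first", "only" and "open" are said of these compounds alone.

Working notes, series with the shared core of compound 1 `CC(C)Cc1cc(-c2cccc(Cn3ccnc3)c2)c(S(=O)(=O)NC(=O)OC(C)C)s1` and compound 2 `CCC(C)OC(=O)NS(=O)(=O)c1sc(CC(C)C)cc1-c1cccc(Cn2ccnc2)c1`. In an assay on HEK293 cells for displacement of a labelled ligand from Type-2 angiotensin II receptor (Homo sapiens), read by scintillation counting, with a stated time of 240 min (on this read-out higher numbers stand for weaker inhibition and lower numbers for stronger inhibition), compound 1 gives 160 nM and compound 2 gives 440 nM, the higher of the two numbers, the step being a 2.8-fold higher number from compound 1 to compound 2 (0.44 log units; beyond the scatter). Compound 3 `CC(C)Cc1cc(-c2cccc(Cn3ccnc3)c2)c(S(=O)(=O)NC(=O)C2CC2)s1` carries cyclopropyl in place of sec-butoxy on a carbonyl carbon. Within the data shown here, that measured step touches only the chain beyond the oxygen, whereas here the oxygen itself leaves; no measured step bears on the change directly. A step of unclear direction, and likely within or near the scatter, is therefore expected. Compound 3 is estimated at 300 nM (range 90 nM to 1000 nM), meaning an expected step of a 1.5-fold lower number from compound 2 to compound 3 (0.17 log units; within the scatter).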

Compound 3, inhibition constant: 340 nM
For compound 3 the middle estimate is 1.1-fold (0.05 log units) below the measured one; measured number inside the range.
By their numbers in this assay, from the lowest: compound 1; then compounds 3 and 2 (each within the scatter of the next).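

On a carbonyl carbon, the oxygen of the sec-butoxy group can leave with no change beyond the scatter in this assay: cyclopropyl gives a 1.3-fold lower number from compound 2 to compound 3 (0.11 log units; within the scatter). Set against isopropoxy, the same cyclopropyl gives a 2.1-fold higher number from compound 1 to compound 3 (0.33 log units; beyond the scatter), so compound 1 keeps the lowest number of the three. Nothing available explains either step.

As far as these compounds go, whether methoxy, ethoxy or a dimethylamino group on this carbonyl carbon would read closer to compound 1 or to compound 3 remains open. So does whether a larger ring such as cyclobutyl or cyclopentyl would read like cyclopropyl.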